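This account rests on a few compounds, and the source may have more. Where it says the series, first, only, none or still open, it means among the compounds named here.

Compound 1 `Clc1ccccc1Cn1nnc2c(NC3CCC3)nc(-c3ccccc3)nc21` is, in an assay on isolated protein for binding affinity to adenosine receptor A1 (Bos taurus) (on this read-out lower numbers stand for stronger inhibition and higher numbers for weaker inhibition), the weaker binder of the two compounds measured here, giving 24000000 nM. Within the data shown here, compound 2 `c1ccc(Cn2nnc3c(NC4CCC4)nc(-c4ccccc4)nc32)cc1` gives 5000000 nM in this assay, and the only measured step, a 4.8-fold lower number from compound 1 to compound 2 (0.68 log units; beyond the scatter), concerns a change on the aromatic ring that carries the chloro group. Compound 3 `COc1ccc(C(=O)Nc2nc(-c3ccccc3)nc3c2nnn3Cc2ccccc2Cl)cc1` differs from compound 1 elsewhere: (4-methoxyphenyl)carbonyl in place of cyclobutyl on a nitrogen on an aromatic ring. Among the measured compounds shown here, no measured step touches this part of the shared core, so the expectation rests on no direct comparison. Compound 3 is therefore expected to give roughly 10000000 nM in this assay, between 1000000 nM and 50000000 nM, an expected step of a 2.4-fold lower number from compound 1 to compound 3 (0.38 log units; beyond the scatter).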

Compound 3, inhibition constant: 20000000 nM
The estimate for compound 3 lay 2.0-fold (0.30 log units) below the measured number; the range from low to high includes it.
By their numbers in this assay, from the lowest: compound 2; then compounds 3 and 1 (each within the scatter of the next).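

At this nitrogen, the step from cyclobutyl to (4-methoxyphenyl)carbonyl, a group of 10 heavy atoms instead of 4 that also brings a carbonyl next to the nitrogen's ring substituent position, gives a 1.2-fold lower number from compound 1 to compound 3 (0.08 log units; within the scatter) in this assay. So the earlier chloro step said nothing about this place, and here a far bigger change in the group leaves the reading inside the scatter. No measurement shown offers an explanation for this. As far as these compounds go, whether an acetyl group or a longer alkyl chain on this nitrogen would read the same stays open. So does whether this swap gives the same reading on compound 2, which carries hydrogen in place of chloro.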